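The source may report more compounds than this note shows. Statements on the series, on what has been measured and on what is new or still open speak of the compounds shown alone.

In a functional assay on cells (Endothelial cell, Bos taurus) for antiproliferative activity (a higher number here means a weaker inhibitor, a lower number a stronger inhibitor), compound 1 `COc1ccc(/C=C(\F)c2cc(OC)c(OC)c(OC)c2)cc1O` gives 13000 nM while compound 2 `COc1ccc(/C=C(/F)c2cc(OC)c(OC)c(OC)c2)cc1[N+](=O)[O-]` gives 38400 nM and compound 3 `COc1ccc(/C=C(\F)c2cc(OC)c(OC)c(OC)c2)cc1N` gives 86000 nM as the highest number of the three. Compound 4 `COc1ccc(/C=C(\F)c2cc(OC)c(OC)c(OC)c2)cc1[N+](=O)[O-]` has nitro in place of amino on an aromatic carbon, ortho to a methoxy group and meta to a large group (nitro in place of amino on an aromatic carbon). For the measured compounds named here, the only measured step at this place, amino in place of hydroxy, is a 6.6-fold higher number from compound 1 to compound 3 (0.82 log units; beyond the scatter) and counts as modest. Going by the values given here, compound 2 carries nitro at the same place with the other geometry at the double bond and gives 38400 nM as the only nitro value measured. On these two grounds the expected step of a 2.9-fold lower number from compound 3 to compound 4 (0.46 log units; beyond the scatter) is modest and runs to a lower number in this assay as estimated here. The estimate for compound 4 is 30000 nM with 9000 nM to 90000 nM as its expected range.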

Compound 4, half-maximal inhibitory concentration: 2800000 nM
Estimate against measurement, compound 4: 93-fold (1.97 log units) below, outside the stated range (above it).
By their numbers in this assay, from the lowest: compound 1; then compound 2; then compound 3; then compound 4.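

In this assay nitro at this position proves far from a mild replacement, giving against amino a 33-fold higher number from compound 3 to compound 4 (1.51 log units; beyond the scatter) and against hydroxy a 220-fold higher number from compound 1 to compound 4 (2.33 log units; beyond the scatter). The effect of nitro here depends heavily on the double bond, with a 73-fold higher number from compound 2 to compound 4 (1.86 log units; beyond the scatter) separating the two nitro compounds, a gap that can be laid on geometry alone: the fact that compounds 2 and 4 differ only in the configuration as drawn.

Hydroxy and amino each appear with one double bond geometry only, so whether they depend on it as nitro does stays open. Going by these compounds, how a carboxylic acid or a methyl ester would behave at this position also remains unknown.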